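Cyano on the pyridine of two ether and ketone cores

The source may report more compounds than this note shows. Statements on the series, on what has been measured and on what is new or still open speak of the compounds shown alone.

Measured so far in a functional assay on HEK293 cells for negative allosteric modulation of metabotropic glutamate receptor 5 (Rattus norvegicus), read by FLIPR and calcium flux, with a stated time of 170 s; on this read-out lower numbers stand for stronger inhibition and higher numbers for weaker inhibition:
Compound 1 `c1ccc(COc2cc3n(n2)CCCC3)nc1` gives 2500 nM.
Compound 2 `N#Cc1ccc(COc2cc3n(n2)CCCC3)nc1` gives 316 nM.
Compound 3 `O=C(Cc1ccccn1)c1cc2n(n1)CCCC2` gives 390 nM.

Compound 1 and compound 2 share a core and differ only by cyano in place of hydrogen on an aromatic carbon; this change gives a 7.9-fold lower number from compound 1 to compound 2 (0.90 log units; beyond the scatter). Compound 3 carries a different core; how it differs from the core of compound 1 is not broken down here. Against compound 2 the number for compound 3 is within the scatter, so no order between the two is claimed.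

Compound 4 `N#Cc1ccc(CC(=O)c2cc3n(n2)CCCC3)nc1` is not yet measured. It differs from compound 3 by cyano in place of hydrogen on an aromatic carbon, the same kind of change as that from compound 1 to compound 2, on a place described in the same words. In this assay, within the data shown here, the step from compound 3 to compound 4 is expected to be a 6.5-fold lower number from compound 3 to compound 4 (0.81 log units; beyond the scatter), resting on the single precedent a 7.9-fold lower number from compound 1 to compound 2 (0.90 log units; beyond the scatter), with some allowance for the core being different and the change having been seen only once. Compound 4 is therefore estimated at 60 nM, with a likely range from 25 nM to 200 nM.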

Compound 4, half-maximal inhibitory concentration: 53 nM
Compound 4: the middle estimate sits 1.1-fold (0.05 log units) above what was measured, within the range that was stated.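

In this assay, cyano in place of hydrogen on an aromatic carbon gives a 7.4-fold lower number from compound 3 to compound 4 (0.87 log units; beyond the scatter), so the change again moves the number by a step beyond the scatter. Set beside the earlier step, the change carries from one core to the other at much the same size: the same change on two cores in this assay, a 7.9-fold lower number (0.90 log units; beyond the scatter) from compound 1 to compound 2 and a 7.4-fold lower number (0.87 log units; beyond the scatter) from compound 3 to compound 4, 1.1-fold (0.03 log units) apart, within the scatter of two such steps. Among these compounds, this agreement rests on only two matched pairs, both with the cyano on a six-membered aromatic ring with 1 nitrogen, two atoms from the ring nitrogen and para to a large group, so it shows transfer between these two cores only and says nothing about any other core or any other read-out.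

On these data alone, whether a group other than cyano at this place, such as chlorine, methoxy or an amine, would give a step of similar size remains open. Also open, as far as these compounds go, is whether the size of the step holds on a core with a longer chain in place of the ether or ketone link.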